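Working notes: from compound 3 to compound 4

The source may report more compounds than this note shows. Statements on the series, on what has been measured and on what is new or still open speak of the compounds shown alone.

In a functional assay on MCF7 cells (Homo sapiens) for antiproliferative activity, read by MTT assay (a lower number here means a stronger inhibitor, a higher number a weaker inhibitor), compound 1 `COc1cc2c(Oc3ccc(NC(=O)Nc4ccc(C(F)(F)F)cc4Cl)cc3)ccnc2cc1OCCCCCCC(=O)NO` gives 500 nM while compound 2 `COc1cc2c(Oc3ccc(NC(=O)Nc4ccc(Cl)c(C(F)(F)F)c4)cc3)ccnc2cc1OCCCCCCC(=O)NO` gives 5150 nM and compound 3 `COc1cc2c(Oc3ccc(NC(=O)NC4CCCCC4)cc3)ccnc2cc1OCCCCCCC(=O)NO` gives 600 nM on the same scale. The step of a 1.2-fold higher number from compound 1 to compound 3 (0.08 log units; within the scatter) stays within the scatter and the step of an 8.6-fold lower number from compound 2 to compound 3 (0.93 log units; beyond the scatter) goes beyond it, which leaves compound 3 in the lower pair of numbers.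

Within the data shown here, compound 4 `COc1cc2c(Oc3ccc(NC(=O)N/N=C/c4ccc(F)cc4)cc3)ccnc2cc1OCCCCCCC(=O)NO` differs from compound 3 by a group of 9 heavy atoms (7 carbon, 1 nitrogen, 1 fluorine; one six-membered aromatic ring of carbon only) in place of a group of 6 heavy atoms (6 carbon; one six-membered non-aromatic ring of carbon only), on an amide-type nitrogen and no measured compound carries the entering group. The step of a 10-fold higher number from compound 1 to compound 2 (1.01 log units; beyond the scatter) shows that changes on this amide-type nitrogen can be large, though the cyclohexyl and 2-chloro-4-(trifluoromethyl)phenyl compounds read alike. The estimated move is a 1.7-fold higher number from compound 3 to compound 4 (0.22 log units; within the scatter) in this assay and so a slight upward lean is expected, with no step beyond the scatter. Compound 4 is estimated at 1000 nM with an expected range from 300 nM to 3500 nM in this series.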

Compound 4, half-maximal inhibitory concentration: 1360 nM
Estimate against measurement, compound 4: 1.4-fold (0.13 log units) below, and the stated range covers the measured number.
By their numbers in this assay, from the lowest: compounds 1 and 3 (each within the scatter of the next); then compound 4; then compound 2.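

In this assay, the group with a double bond outside aromatic rings and a fluorine on its aromatic ring gives a 2.3-fold higher number from compound 3 to compound 4 (0.36 log units; beyond the scatter) and a 2.7-fold higher number from compound 1 to compound 4 (0.43 log units; beyond the scatter) on one side and a 3.8-fold lower number from compound 2 to compound 4 (0.58 log units; beyond the scatter) on the other, so compound 4 takes a middle place in the series. This amide-type nitrogen therefore carries three levels of number rather than two. No measurement bears on the reason for this reading.

The compounds shown do not separate the contribution of the double bond from that of the fluorine. An unsubstituted benzyl group on the same nitrogen would bear on that question.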